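Chloro to Trifluoromethyl in an Acrylamide Series

The source may report more compounds than this note shows. Statements on the series, on what has been measured and on what is new or still open speak of the compounds shown alone.

Measured compounds:
compound 1, `C=CC(=O)Nc1cccc(NC(=O)CSc2nc(Nc3cccc(C)c3)c3ccccc3n2)c1`, 20900 nM
compound 2, `C=CC(=O)Nc1cccc(NC(=O)CSc2nc(Nc3ccc(Cl)cc3)c3ccccc3n2)c1`, 14300 nM

In a functional assay on MGC-803 cells (Homo sapiens) for inhibition, read by MTT assay, with a stated time of 72 h (a lower number here means a stronger inhibitor, a higher number a weaker inhibitor), compound 1 gives 20900 nM, while compound 2 gives 14300 nM. Going by the values given here, the single measured step, a 1.5-fold lower number from compound 1 to compound 2 (0.16 log units; within the scatter), leaves compound 2 within the scatter of compound 1, so neither stands apart. Compound 3 `C=CC(=O)Nc1cccc(NC(=O)CSc2nc(Nc3ccc(C(F)(F)F)cc3)c3ccccc3n2)c1` differs from compound 2 by trifluoromethyl in place of chloro on an aromatic carbon. Among the compounds with values here, no measured step swaps chloro for trifluoromethyl; the only comparison, a 1.5-fold lower number from compound 1 to compound 2 (0.16 log units; within the scatter), changed the same ring without a step beyond the scatter. The expected step is a 1.0-fold lower number from compound 2 to compound 3 (0.01 log units; within the scatter), within the scatter. Compound 3 is therefore estimated at 14000 nM, between 5000 nM and 40000 nM.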

Compound 3, half-maximal inhibitory concentration: 12100 nM
Compound 3: the middle estimate sits 1.2-fold (0.06 log units) above what was measured; the measured number falls inside the stated range.
By their numbers in this assay, from the lowest: compounds 3, 2 and 1 (each within the scatter of the next).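

In this assay, the exchange of chloro for trifluoromethyl, four heavy atoms in place of one, gives a 1.2-fold lower number from compound 2 to compound 3 (0.07 log units; within the scatter) and so adds a second step at this ring that stays within the scatter. The wider change from 3-methylphenyl to 4-(trifluoromethyl)phenyl gives a 1.7-fold lower number from compound 1 to compound 3 (0.24 log units; within the scatter) and also stays within it, so the three groups are not separated here. Nothing available bears on why these numbers lie so close. On these data alone, whether an amine or a carboxylic acid on this aromatic carbon would move the number beyond the scatter remains open.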